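From compound 3 to compound 4: adding a methoxy group

A few compounds are considered here, and "the series" means these few. Any claim that something is new, unique, unknown or untested is made for them only; others in the source may bear on it.

Measured in a functional assay on A549 cells (Homo sapiens) for antiproliferative activity, read by MTT assay, with a stated time of 48 h (a higher number here means a weaker inhibitor, a lower number a stronger inhibitor), so far:
Compound 1 `O=C(/C=C/c1ccc(C(F)(F)F)cc1)Nc1nnc(-c2ccc(Br)cc2)s1` gives 4.68 ug/mL
Compound 2 `COc1ccc(/C=C/C(=O)Nc2nnc(-c3ccccc3)s2)cc1` gives 0.76 ug/mL
Compound 3 `O=C(/C=C/c1ccccc1)Nc1nnc(-c2ccc(Br)cc2)s1` gives 2.18 ug/mL

In this assay compound 3 at 2.18 ug/mL holds the middle place, with compound 1 higher at 4.68 ug/mL and compound 2 lower at 0.76 ug/mL on the same scale. Compound 4 `COc1ccc(/C=C/C(=O)Nc2nnc(-c3ccc(Br)cc3)s2)cc1` has not yet been measured. It has methoxy in place of hydrogen on an aromatic carbon of a six-membered aromatic ring of carbon only, para to a large group methoxy in place of hydrogen on an aromatic carbon and is otherwise the same as compound 3.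

Among the measured compounds shown here, one measured step bears on this change, and it is modest: a 2.1-fold lower number from compound 1 to compound 3 (0.33 log units; beyond the scatter) with hydrogen in place of trifluoromethyl. That step involves a different group, so it offers only a guide to size. For the measured compounds named here, compound 2 carries the methoxy but lacks the bromine, and at 0.76 ug/mL it points towards a lower number, though no measured pair isolates the methoxy. A lower number is therefore expected, by a step no larger than a modest one. The estimate means a 1.7-fold lower number from compound 3 to compound 4 (0.22 log units; within the scatter) as the expected step for this change. For compound 4 the expected value is 1.3 ug/mL with an estimated range from 0.5 ug/mL to 3.2 ug/mL in this measurement.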

Compound 4, half-maximal inhibitory concentration: 1.04 ug/mL
Estimate against measurement, compound 4: 1.3-fold (0.10 log units) above; the range from low to high includes it.
By their numbers in this assay, from the lowest: compounds 2 and 4 (each within the scatter of the next); then compound 3; then compound 1.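

In this assay the methoxy group, para to a large group, now has a step of its own: the change from phenyl to 4-methoxyphenyl gives a 2.1-fold lower number from compound 3 to compound 4 (0.32 log units; beyond the scatter) with the bromo kept in place. The bromo itself shows no readable effect, as its step is a 1.4-fold higher number from compound 2 to compound 4 (0.14 log units; within the scatter) and so stays within the scatter. With the bromo held constant, methoxy in place of trifluoromethyl gives a 4.5-fold lower number from compound 1 to compound 4 (0.65 log units; beyond the scatter), so among the three groups tried at this position the number falls from trifluoromethyl through hydrogen to methoxy.

Going by these compounds, whether an amine or a carboxylic acid at this position would extend that order remains open, as does whether the methoxy step holds on a compound without the bromo. Nothing in hand explains why the number moves with these groups.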